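This account rests on a few compounds, and the source may have more. Where it says the series, first, only, none or still open, it means among the compounds named here.

Measured in a functional assay on HCT-116 cells (Homo sapiens) for inhibition; a higher number here means a weaker inhibitor of growth, a lower number a stronger inhibitor of growth:
- compound 1 `Nc1ncc(-c2ccc(Cl)c([N+](=O)[O-])c2)cn1`: > 50000 nM (a limit)
- compound 2 `CN(Cc1ccccc1)c1ccc(-c2cnc(N)nc2)cc1[N+](=O)[O-]`: > 50000 nM (a limit)
- compound 3 `Nc1ncc(-c2ccc(NCc3ccc(Cl)cc3)c([N+](=O)[O-])c2)cn1`: 3000 nM

Among the compounds with values here, compound 3 gives the only true number, 3000 nM. Compound 1 and compound 2 give no number, only (the limit of > 50000 nM in this assay, at which 2 of the 3 values shown sit).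

Compound 4 `Nc1ncc(-c2ccc(NCc3ccc(F)cc3)c([N+](=O)[O-])c2)cn1` keeps the rest of compound 3 and changes one substituent: fluoro in place of chloro on an aromatic carbon. This is fluoro in place of chloro on an aromatic carbon, para to a large group, so 4-chlorobenzyl becomes 4-fluorobenzyl. Within the data shown here, no measured pair differs in one place only, so the size of this step has no direct precedent.

In this assay, a small move towards weaker growth inhibition is expected, not far beyond the scatter, and the estimate stays anchored on compound 3 at 3000 nM. The estimated change is a 1.5-fold higher number from compound 3 to compound 4 (0.18 log units; within the scatter). For compound 4 the expected value is 4500 nM, with an estimated range of 1800 nM to 14000 nM.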

Compound 4, concentration for 50% growth inhibition: 48000 nM
The estimate for compound 4 lay 11-fold (1.03 log units) below the measured number, and the stated range ends below it.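

In this assay, the exchange of 4-chlorobenzyl for 4-fluorobenzyl gives a 16-fold higher number from compound 3 to compound 4 (1.20 log units; beyond the scatter), so a single halogen swap on this aromatic carbon, para to a large group, is enough to change the read-out well beyond the scatter. Within the data shown here, this is the first comparison that differs in one place only, and it shows that the growth inhibition of compound 3 does not carry over to fluoro at this position. Compound 1 and compound 2 remain limits rather than numbers: the limit of > 50000 nM in this assay, at which 2 of the 4 values shown sit.

As far as these compounds go, how bromo, methyl or methoxy would read at this position stays open, as does plain benzyl with hydrogen there. The compounds shown give no cause for the step, and whether it holds on a longer chain, such as 2-phenylethyl in place of benzyl, also stays open.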